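This account rests on a few compounds, and the source may have more. Where it says the series, first, only, none or still open, it means among the compounds named here.

Working notes on the series. In a functional assay on K562 cells (Homo sapiens) for cytotoxicity, read by trypan blue exclusion, with a stated time of 96 h (on this read-out higher numbers stand for weaker inhibition and lower numbers for stronger inhibition), compound 1 `COc1ccc(CS(=O)(=O)/C=C/c2ccccc2OC)cc1N` gives 7500 nM, and compound 3 `COc1ccc(OC)c(/C=C/S(=O)(=O)Cc2ccc(OC)c(N)c2)c1` gives 750 nM. The change between them is methoxy in place of hydrogen on an aromatic carbon, and it gave a 10-fold lower number from compound 1 to compound 3 (1.00 log units; beyond the scatter). Compound 2 `COc1ccc(CS(=O)(=O)/C=C/c2c(OC)cccc2OC)cc1[N+](=O)[O-]` gives 20000 nM in this assay, the highest number of the three measured compounds; how its core differs from that of compound 1 is not broken down here. Compound 4 `COc1cc(OC)c(/C=C/S(=O)(=O)Cc2ccc(OC)c([N+](=O)[O-])c2)c(OC)c1` carries the same kind of change relative to compound 2, (methoxy in place of hydrogen on an aromatic carbon), but the surroundings differ: in compound 3 the methoxy sits meta to a large group and para to a methoxy group, while in compound 4 it sits meta to two methoxy groups and para to a large group. Because of the size of a 10-fold lower number from compound 1 to compound 3 (1.00 log units; beyond the scatter), a lowering is expected for compound 4 as well, and the estimated step is a smaller one, a 4.0-fold lower number from compound 2 to compound 4 (0.60 log units; beyond the scatter), since the placement and the core differ. Compound 4 is therefore estimated at 5000 nM in this assay, between 1200 nM and 18000 nM.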

Compound 4, half-maximal inhibitory concentration: 2500 nM
The estimate for compound 4 lay 2.0-fold (0.30 log units) above the measured number; the range from low to high includes it.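

In this assay, methoxy in place of hydrogen on an aromatic carbon gave an 8.0-fold lower number from compound 2 to compound 4 (0.90 log units; beyond the scatter). For the compounds shown here, the step carried over from one core to the other at a similar size: the same change on two cores in this assay, a 10-fold lower number (1.00 log units; beyond the scatter) from compound 1 to compound 3 and an 8.0-fold lower number (0.90 log units; beyond the scatter) from compound 2 to compound 4, 1.3-fold (0.10 log units) apart, within the scatter of two such steps These are only two pairs, and they differ in both the core and the placement of the methoxy; they do not show that the step would hold on further cores, nor do they separate the contribution of core from that of placement.

Going by these compounds, it remains open whether another group in place of this methoxy, such as ethoxy, hydroxy or chlorine, would give a step of similar size. On these data alone, the effect of a longer alkoxy chain at this place also remains open.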